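Swapping pyridin-4-yl for pyridin-2-yl

A few compounds are considered here, and "the series" means these few. Any claim that something is new, unique, unknown or untested is made for them only; others in the source may bear on it.

In a functional assay on RPMI 8402 cells (Homo sapiens) for cytotoxicity (on this read-out higher numbers stand for weaker inhibition and lower numbers for stronger inhibition), compound 1 `c1ccc(-c2ccc3[nH]c(-c4ccc5[nH]c(-c6ccc7[nH]cnc7c6)nc5c4)nc3c2)cc1`, which carries a phenyl group on the shared core, gives 580 nM. Compound 2 `c1cncc(-c2ccc3[nH]c(-c4ccc5[nH]c(-c6ccc7[nH]cnc7c6)nc5c4)nc3c2)c1` gives 2500 nM, and compound 3 `c1cc(-c2ccc3[nH]c(-c4ccc5[nH]c(-c6ccc7[nH]cnc7c6)nc5c4)nc3c2)ccn1` gives 2500 nM. Compound 3 therefore stands level with compound 2, the pair sharing the highest number of the three.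

Compound 4 `c1ccc(-c2ccc3[nH]c(-c4ccc5[nH]c(-c6ccc7[nH]cnc7c6)nc5c4)nc3c2)nc1` has pyridin-2-yl in place of pyridin-4-yl on an aromatic carbon.

Replacing phenyl gave a 4.3-fold higher number from compound 1 to compound 2 (0.63 log units; beyond the scatter) and a 4.3-fold higher number from compound 1 to compound 3 (0.63 log units; beyond the scatter). For the measured compounds named here, exchanging one pyridine group for another, the closest precedent, gave no change at the digits printed from compound 2 to compound 3 (within the scatter). That single exchange is thin evidence, but no step beyond the scatter is expected, and the estimated step is a 1.3-fold lower number from compound 3 to compound 4 (0.10 log units; within the scatter). Compound 4 is expected at 2000 nM, within a range of 800 nM to 5000 nM.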

Compound 4, half-maximal inhibitory concentration: 5800 nM
Compound 4: the middle estimate sits 2.9-fold (0.46 log units) below what was measured; measured number outside the range, above it.
By their numbers in this assay, from the lowest: compound 1; then compounds 2 and 3 (each within the scatter of the next); then compound 4.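

In this assay the pyridines at this position can be told apart after all: pyridin-2-yl gives a 2.3-fold higher number from compound 3 to compound 4 (0.37 log units; beyond the scatter) and a 2.3-fold higher number from compound 2 to compound 4 (0.37 log units; beyond the scatter) while pyridin-3-yl and pyridin-4-yl stay level. Set against phenyl, the same group gives a 10-fold higher number from compound 1 to compound 4 (1.00 log units; beyond the scatter) so that, of these four groups, phenyl has the lowest number and pyridin-2-yl the highest. Nothing shown here explains why pyridin-2-yl stands apart from the other two pyridines. Still open, going by these compounds, is how a phenyl group carrying an amine or a carboxylic acid would compare with compound 1.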